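Thiophen-2-yl Ether in Place of the Acetyl Ester

A few compounds are considered here, and "the series" means these few. Any claim that something is new, unique, unknown or untested is made for them only; others in the source may bear on it.

Measured compounds:
- compound 1 `CC(=O)Oc1ccc2c(c1)C(=O)C=CC2=O`: 27700 nM
- compound 2 `CS(=O)(=O)OC1=CC(=O)c2ccccc2C1=O`: 7610 nM
- compound 3 `O=C1C=CC(=O)c2c(Oc3ccco3)cccc21`: 12500 nM

Of the compounds shown here, three share a core and have been tested in a functional assay on HeLa cells (Homo sapiens) for cytotoxicity; a higher number here means a weaker inhibitor, a lower number a stronger inhibitor. Compound 1 has the highest number of the three: compound 3 sits a little lower, beyond the usual scatter, and compound 2 lower still. Compound 4 `O=C1C=CC(=O)c2cc(Oc3cccs3)ccc21` has not been measured yet. It differs from compound 1 in one place: thiophen-2-yl in place of acetyl on an oxygen on an aromatic ring. Compound 3 also carries an aromatic ether on the core rather than an ester, though at another position, and in this assay compound 3 gives 12500 nM, a lower number than compound 1. For the measured compounds named here, no direct step between two measured compounds covers this kind of change, so the expectation rests on that comparison alone. The step of a 2.1-fold lower number from compound 1 to compound 4 (0.33 log units; beyond the scatter) is expected to be modest, towards a lower number, and near the edge of the scatter. For compound 4 an estimated value of 13000 nM is expected, with a range from 5000 nM to 32000 nM.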

Compound 4, half-maximal inhibitory concentration: 8860 nM
The estimate for compound 4 lay 1.5-fold (0.17 log units) above the measured number; measured number inside the range.
By their numbers in this assay, from the lowest: compounds 2, 4 and 3 (each within the scatter of the next); then compound 1.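

In this assay, for the compounds shown here, thiophen-2-yl in place of acetyl on an oxygen on an aromatic ring gives a 3.1-fold lower number from compound 1 to compound 4 (0.50 log units; beyond the scatter) and is the first single-change comparison in this set. At this position, then, the acetoxy group is not required for a measurable effect on these cells, and a (thiophen-2-yl)oxy group gives a lower number.

The compounds shown leave open whether the thiophene ring itself matters, or whether a simple phenyl or methyl group on the same oxygen would give a similar number. Going by these compounds, how an amine, a carboxylic acid or a longer alkyl chain would behave at this place also remains unknown. No supporting measurement is available to explain the step between these two compounds.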